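A few compounds are considered here, and "the series" means these few. Any claim that something is new, unique, unknown or untested is made for them only; others in the source may bear on it.

Measured so far in an assay on isolated protein for inhibition of Nitric oxide synthase, inducible (Homo sapiens), read by scintillation counting, with a stated time of 30 min, tested at 50 uM; a lower number here means less inhibition, a higher number more inhibition at the concentration tested (going by the name of the read-out):

Compound 1 `CC(=O)N1N=C(c2cc(Cl)ccc2N)SC1(C)C`: 72.8%
Compound 2 `CC1(C)SC(c2cc(Cl)ccc2N)=NN1C(=O)C1CC1`: 23.2%
Compound 3 `CC1(C)SC(c2cc(Cl)ccc2N)=NN1C(=O)C1CCC1`: -4.65%

Compound 3 stands lowest of the three; compound 2 is nearest, compound 1 furthest, and both gaps lie beyond the scatter. The three steps all concern the group on the carbonyl carbon: a number 49.6 percentage points lower from compound 1 to compound 2 (beyond the scatter), a number 77.5 percentage points lower from compound 1 to compound 3 (beyond the scatter) and a number 27.9 percentage points lower from compound 2 to compound 3 (beyond the scatter). Each enlargement of that ring lowered inhibition. Compound 4 `CC1(C)SC(c2cc(Cl)ccc2N)=NN1C(=O)C1CCCCC1` differs from compound 3 by cyclohexyl in place of cyclobutyl on a carbonyl carbon. The earlier steps shown here bear on it directly, yet compound 3 already sits near zero, so only a small further downward step is expected, probably within the scatter. Compound 4 is therefore expected to give -8%, between -25% and 12%, a step of a number 3.4 percentage points lower from compound 3 to compound 4 (within the scatter).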

Compound 4, a percentage reported as inhibition, at one concentration (the size of the read-out at that concentration, not a potency): 7.61%
For compound 4 the middle estimate is 15.6 percentage points below the measured one; measured number inside the range.
By their numbers in this assay, from the lowest: compound 3; then compound 4; then compound 2; then compound 1.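

Cyclohexyl on this carbonyl carbon breaks the fall seen as the ring grew, with a number 12.3 percentage points higher from compound 3 to compound 4 (beyond the scatter) in this assay, so inhibition does not simply drop with ring size. Even so, cyclohexyl stays short of the smaller groups, with a number 15.6 percentage points lower from compound 2 to compound 4 (beyond the scatter) and a number 65.2 percentage points lower from compound 1 to compound 4 (beyond the scatter), and methyl remains the highest of the four. Nothing available explains this reversal. Still open, from the compounds shown here alone, is how an open chain such as ethyl or a longer chain would behave in this place, and whether a ring carrying an amine would recover inhibition.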